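Swapping Fluoro for Bromo on a Calpain-1 Inhibitor Core

The compounds below may be only part of what the source reports. "The series", "measured", "known", "first", "only" and "open" are said of these compounds alone.

Measured so far:
compound 1 `O=C(O)/C(S)=C/c1c[nH]c2cccc(F)c12`: 10 nM
compound 2 `O=C(O)/C(S)=C/c1c[nH]c2ccc(Cl)cc12`: 250 nM
compound 3 `O=C(O)/C(S)=C/c1ccc(I)cc1`: 2200 nM

In an assay on isolated protein for inhibition of Calpain-1 catalytic subunit (Sus scrofa), read by FRET (on this read-out higher numbers stand for weaker inhibition and lower numbers for stronger inhibition), compound 1 gives the lowest number of the three. Compound 2 gives 250 nM, a gap beyond the scatter, and compound 3 gives 2200 nM, further away still. Compound 4 `O=C(O)/C(S)=C/c1c[nH]c2cccc(Br)c12` has not yet been measured. It differs from compound 1 in one place: bromo in place of fluoro on an aromatic carbon. For the measured compounds named here, no measured pair shows such a change on this core, so the size of the step is unknown; a change no larger than the scatter, in either direction, seems most likely. Compound 4 is expected to give 15 nM, within a range from 4 nM to 60 nM, an estimated step of a 1.5-fold higher number from compound 1 to compound 4 (0.18 log units; within the scatter).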

Compound 4, half-maximal inhibitory concentration: 6 nM
Beside the measured number, compound 4's estimate is 2.5-fold (0.40 log units) above it; the range from low to high includes it.
By their numbers in this assay, from the lowest: compounds 4 and 1 (each within the scatter of the next); then compound 2; then compound 3.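

In this assay, bromo in place of fluoro on an aromatic carbon gives a 1.7-fold lower number from compound 1 to compound 4 (0.22 log units; within the scatter), the first step seen at this position. On the core of compound 1, then, these two halogens cannot be told apart at this place, and a heavier halogen atom does not cost inhibition here. Nothing available explains why the two halogens read alike. Still open, from the compounds shown here alone, is whether this tolerance extends beyond halogens, for example to an amine, a methoxy group or a longer chain at the same carbon.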